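The source may report more compounds than this note shows. Statements on the series, on what has been measured and on what is new or still open speak of the compounds shown alone.

The series rests on one shared core, varied only at the saturated chain carbon bound to the amine nitrogen in a ring. Compound 1 `O=C(O)c1cncc(CN2CCC[C@H](O[C@H](CO)c3cc(Cl)cc(Cl)c3)[C@@H]2c2ccccc2)c1` carries there a group of 9 heavy atoms with one six-membered aromatic ring with 1 hetero atom; in an assay on isolated protein for activation of cGMP-dependent protein kinase 1 (Homo sapiens), read by ADP-Glo, with stated times of 120 min and 40 min (a lower number here means that less compound is needed, a higher number that more compound is needed for the effect), compound 1 gives 34000 nM. Among the measured compounds shown here, compound 2 `OC[C@@H](O[C@H]1CCCN(Cc2cccc3nonc23)[C@H]1c1ccccc1)c1cc(Cl)cc(Cl)c1` gives 8000 nM in this assay, the lowest of the two numbers measured so far, and the change a 4.3-fold lower number from compound 1 to compound 2 (0.63 log units; beyond the scatter) lies beyond the scatter. Compound 3 `OC[C@@H](O[C@H]1CCCN(Cc2ccccc2Cc2nnco2)[C@H]1c1ccccc1)c1cc(Cl)cc(Cl)c1` is the next step from compound 2: a group of 12 heavy atoms (9 carbon, 2 nitrogen, 1 oxygen; one five-membered aromatic ring with 3 hetero atoms, one six-membered aromatic ring of carbon only) in place of a group of 9 heavy atoms (6 carbon, 2 nitrogen, 1 oxygen; one five-membered aromatic ring with 3 hetero atoms, one six-membered aromatic ring of carbon only), on a saturated chain carbon bound to an amine nitrogen in a ring. For the measured compounds named here, only the step from compound 1 to compound 2 touches the same place, and it concerns a different exchange, so no measured step bears directly on this change; the data give no comparison of the two groups that are swapped here. Compound 3 is therefore expected to land close to compound 2, the expected step of a 1.3-fold higher number from compound 2 to compound 3 (0.10 log units; within the scatter) being small and within what repeated measurements would show. The estimate for compound 3 in this assay is 10000 nM, with a range from 3000 nM to 40000 nM.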

Compound 3, half-maximal effective concentration: 3700 nM
Compound 3: middle estimate off by 2.7-fold (0.43 log units), on the high side, within the range that was stated.
By their numbers in this assay, from the lowest: compound 3; then compound 2; then compound 1.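

At the saturated chain carbon bound to an amine nitrogen in a ring, the group of 12 heavy atoms gives a 2.2-fold lower number from compound 2 to compound 3 (0.33 log units; beyond the scatter) in this assay and so improves on the group of 9 heavy atoms that had held the lowest number. Among the compounds shown here, measured against the group with one six-membered aromatic ring with 1 hetero atom, it gives a 9.2-fold lower number from compound 1 to compound 3 (0.96 log units; beyond the scatter) and thereby widens the gap first seen with compound 2, so both groups with one five-membered aromatic ring with 3 hetero atoms and one six-membered aromatic ring of carbon only now stand lower than that group, with no compound here going against this. No measurement at hand accounts for either step.

The three compounds cannot separate the effect of the additional heavy atoms in compound 3 from that of how its two rings are arranged, and they do not show whether the five-membered ring is needed at all. Going by these compounds, it also stays open how an amine or a longer chain at this place would compare with the group in compound 3, and whether any such change holds on a different core.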